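Replacing the Cyclooctyl Group with a Short Fluorinated Chain

The source may hold more compounds than are shown below. What is called first, only, known or untested is meant among the compounds shown, and "the series" means these compounds.

Measured so far:
compound 1 `O[C@@H]1[C@H](O)[C@@H]2C[C@@H]2[C@H]1n1cnc2c(NC3CCC3)nc(Cl)nc21`: 5.9 nM
compound 2 `O[C@@H]1[C@H](O)[C@@H]2C[C@@H]2[C@H]1n1cnc2c(NC3CCCCCC3)nc(Cl)nc21`: 560 nM
compound 3 `O[C@@H]1[C@H](O)[C@@H]2C[C@@H]2[C@H]1n1cnc2c(NC3CCCCCCC3)nc(Cl)nc21`: 1530 nM

All three share one core and differ only in the ring attached to a nitrogen on an aromatic ring. In an assay on CHO cells for displacement of a labelled ligand from adenosine receptor A3 (Homo sapiens), with a stated time of 60 min (on this read-out lower numbers stand for stronger inhibition and higher numbers for weaker inhibition), compound 1 gives 5.9 nM, while compound 3 gives 1530 nM, the highest number of the three. The steps run one way: a 95-fold higher number from compound 1 to compound 2 (1.98 log units; beyond the scatter), a 260-fold higher number from compound 1 to compound 3 (2.41 log units; beyond the scatter) and a 2.7-fold higher number from compound 2 to compound 3 (0.44 log units; beyond the scatter). Each enlargement of the ring on that nitrogen raised the number, so the smallest ring, cyclobutyl, goes with the lowest number.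

Compound 4 `O[C@@H]1[C@H](O)[C@@H]2C[C@@H]2[C@H]1n1cnc2c(NCCCF)nc(Cl)nc21` carries the change (3-fluoropropyl in place of cyclooctyl on a nitrogen on an aromatic ring). For the measured compounds named here, no measured compound bears a chain at this position, so the three steps are only an indirect guide. They show that moving away from cyclooctyl toward smaller groups lowered the number, and the 3-fluoropropyl group is smaller in heavy atoms than even cyclobutyl. A clear fall is therefore expected, although how far is uncertain, since a chain is not a ring. For compound 4 the estimated step is a 38-fold lower number from compound 3 to compound 4 (1.58 log units; beyond the scatter), giving an expected value of 40 nM with a range from 6 nM to 300 nM.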

Compound 4, inhibition constant: 32.4 nM
For compound 4 the middle estimate is 1.2-fold (0.09 log units) above the measured one; measured number inside the range.
By their numbers in this assay, from the lowest: compound 1; then compound 4; then compound 2; then compound 3.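

In this assay the result shows that a ring on this nitrogen is not needed for a low number: the open 3-fluoropropyl chain gives a 47-fold lower number from compound 3 to compound 4 (1.67 log units; beyond the scatter) and a 17-fold lower number from compound 2 to compound 4 (1.24 log units; beyond the scatter), so it sits far below both large rings. The chain still does not match the smallest ring, with a 5.5-fold higher number from compound 1 to compound 4 (0.74 log units; beyond the scatter), so replacing a ring with a chain is not neutral, and compound 1 keeps the lowest number of the four. No measurement available here accounts for the gap between the chain and the cyclobutyl ring or for the gain over the larger rings.

The compounds shown leave open what the fluorine itself contributes, as only a plain propyl chain on the same nitrogen would separate the fluorine from the chain that carries it. Also open, going by these compounds, is how the number follows chain length, which a shorter 2-fluoroethyl or a longer 5-fluoropentyl chain would test, and where a cyclopentyl ring would fall among the rings.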